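The source may report more compounds than this note shows. Statements on the series, on what has been measured and on what is new or still open speak of the compounds shown alone.

Compound 2 `Cc1nc(-c2ccc(C(F)(F)F)cc2)sc1CNc1ccc(CC(C)C(=O)O)cc1` stands at the weaker end of the two values in hand: in a functional assay on CHO cells for agonist activity at Free fatty acid receptor 1 (Homo sapiens) (on this read-out higher numbers stand for an effect only at larger amounts of compound and lower numbers for an effect already at smaller amounts), compound 2 gives 355 nM, the highest of the two numbers, and the nearest neighbour, compound 1 `Cc1nc(-c2ccc(C(F)(F)F)cc2)sc1CNc1ccc(CCC(=O)O)cc1`, gives 67.6 nM. Among the measured compounds shown here, the one step between measured compounds, a 5.3-fold higher number from compound 1 to compound 2 (0.72 log units; beyond the scatter), came from a methyl in place of hydrogen on the saturated chain carbon bound to the carbonyl carbon. Compound 3 `Cc1nc(-c2ccc(C(F)(F)F)cc2)sc1CNc1ccc(C(C)CC(=O)O)cc1` keeps the same atoms joined differently: 1-(carboxymethyl)ethyl in place of 2-carboxypropyl on an aromatic carbon. For the measured compounds named here, the methyl is thus no longer on the carbon bound to the carbonyl but on the carbon bound to the aromatic ring, a placement for which no measured step exists. Going by the values given here, since the only branching step measured was costly, while the unbranched chain of compound 1 was the better one, the expectation for compound 3 is a modest move back toward compound 1, a 1.8-fold lower number from compound 2 to compound 3 (0.25 log units; within the scatter), with an estimated value of 200 nM and a range from 60 nM to 700 nM.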

Compound 3, half-maximal effective concentration: 58.9 nM
Compound 3: the middle estimate sits 3.4-fold (0.53 log units) above what was measured; the whole stated range lies above it.
By their numbers in this assay, from the lowest: compounds 3 and 1 (each within the scatter of the next); then compound 2.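

Moving the methyl from the 2-carboxypropyl chain to the 1-(carboxymethyl)ethyl chain on the aromatic carbon gives a 6.0-fold lower number from compound 2 to compound 3 (0.78 log units; beyond the scatter) in this assay, so the same atoms joined differently do not carry the same cost. Set against the unbranched chain, the methyl in its new place gives a 1.1-fold lower number from compound 1 to compound 3 (0.06 log units; within the scatter), so the chain accepts a methyl on the carbon bound to the aromatic carbon, whereas on the carbon bound to the carbonyl carbon the same methyl came at a cost. Nothing at hand explains this difference between the two placements. Still open, going by these compounds, is whether an ethyl or a hydroxyl in place of that methyl would be accepted as well. Also open, on these data alone, is whether a tetrazole in place of the carboxylic acid would keep the response on this chain.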